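Notes on replacing chloro with methoxy in compound 1

The source may report more compounds than this note shows. Statements on the series, on what has been measured and on what is new or still open speak of the compounds shown alone.

Measured so far:
- compound 1 `COC(=O)Nc1cc(-c2cnc(OC[C@@](C)(N)CC(C)C)c(Cl)c2)ccn1`: 90%
- compound 2 `COC(=O)Nc1cc(-c2ccc(OC[C@@](C)(N)CC(C)C)c(C)c2C)ccn1`: 93%

Both numbers come from an ADME assay on microsomes from liver (Homo sapiens) for metabolic stability, read by LC-MS, using NADPH, with a stated time of 10 min, tested at 0.5 uM; on this read-out higher numbers stand for a more stable compound and lower numbers for a less stable compound. Compound 1 stands within the usual scatter of compound 2, so the two sit level, and no order can be read between them.

Compound 3 `COC(=O)Nc1cc(-c2cnc(OC[C@@](C)(N)CC(C)C)c(OC)c2)ccn1` carries methoxy in place of chloro on an aromatic carbon of the core of compound 1, ortho to the (2-amino-2,4-dimethylpentyl)oxy group: methoxy in place of chloro on an aromatic carbon. Going by the values given here, no measured pair isolates this change, so the step has no direct support. A small fall in this assay is expected, of a size close to the scatter, starting from compound 1 at 90%. The estimated step is a number 6 percentage points lower from compound 1 to compound 3 (within the scatter). For compound 3 the estimated value is 84%, with an expected range of 70% to 95%.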

Compound 3, percent of the compound remaining: 86%
The estimate for compound 3 lay 2 percentage points below the measured number; the range from low to high includes it.
By their numbers in this assay, from the lowest: compounds 3, 1 and 2 (each within the scatter of the next).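

In this assay, going by these compounds alone, methoxy in place of chloro on an aromatic carbon, ortho to a (2-amino-2,4-dimethylpentyl)oxy group, gives a number 4 percentage points lower from compound 1 to compound 3 (within the scatter) and is the only step that isolates one change. Compounds 1 and 2 differ in more than one place and showed nothing about this position alone, whereas compound 1 and compound 3 now give a direct reading: the two groups sit level on this read-out. No supporting measurement bears on this result.

From the compounds shown here alone, whether that level reading extends to other groups at this position, such as fluoro, ethoxy or a nitrile, remains open. Also open, going by these compounds, is whether the same exchange would read alike on the core of compound 2, which has no ring nitrogen.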